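The source may hold more compounds than are shown below. What is called first, only, known or untested is meant among the compounds shown, and "the series" means these compounds.

Measured so far in a functional assay on HL-60 cells (Homo sapiens) for inhibition, read by MTT assay, with a stated time of 48 h, tested at 10 uM; a lower number here means less inhibition of growth, a higher number more inhibition of growth at the concentration tested:
- Compound 1 `CN1CC[C@H](c2c(O)cc(O)c3c(=O)cc(/C=C/c4ccccc4)oc23)[C@H](O)C1`: 91%
- Compound 2 `CN1CC[C@H](c2c(O)cc(O)c3c(=O)cc(/C=C/c4cccc(Cl)c4)oc23)[C@H](O)C1`: 35%

Of these two compounds, compound 2 stands lowest, well under compound 1. Compound 3 `CN1CC[C@H](c2c(O)cc(O)c3c(=O)cc(/C=C/c4c(F)c(F)c(F)c(F)c4F)oc23)[C@H](O)C1` has not yet been measured. It carries 2,3,4,5,6-pentafluorophenyl in place of 3-chlorophenyl on a double-bonded chain carbon bound to a double-bonded chain carbon.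

Among the measured compounds shown here, only one measured step bears on this change: a number 56 percentage points lower from compound 1 to compound 2 (beyond the scatter), with chloro in place of hydrogen on an aromatic carbon. For the measured compounds named here, that step is large, so a change on this phenyl group can clearly matter, but no measured compound carries fluorine. Compound 3 is halogenated like compound 2, so it is expected to stay nearer to that compound's level than to that of compound 1, though with wide uncertainty. The expected result in this assay is a number 10 percentage points higher from compound 2 to compound 3 (within the scatter), a slight rise that need not exceed the scatter. Compound 3 is estimated at 45%, with an expected range from 15% to 80%.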

Compound 3, percent growth inhibition at one concentration: 80%
For compound 3 the middle estimate is 35 percentage points below the measured one, and the stated range covers the measured number.
By their numbers in this assay, from the lowest: compound 2; then compound 3; then compound 1.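

In this assay the change to 2,3,4,5,6-pentafluorophenyl in place of 3-chlorophenyl gives a number 45 percentage points higher from compound 2 to compound 3 (beyond the scatter) and so shows that halogen on this phenyl group does not in itself hold the number at the low level of compound 2. Against the plain phenyl group, the same ring with its five fluorine atoms gives a number 11 percentage points lower from compound 1 to compound 3 (beyond the scatter) and thus costs far less than the single chlorine did, so this place on a double-bonded chain carbon accepts heavy halogen substitution with only a modest loss. Nothing available explains why the two halogenated rings differ so widely.

The compounds shown leave open whether a single fluorine on this ring would track compound 2 or compound 3. They also leave open how a methoxy group or an amine at the same ring would compare.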